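This account rests on a few compounds, and the source may have more. Where it says the series, first, only, none or still open, it means among the compounds named here.

Measured compounds in an ADME assay on HEK-293T cells (Homo sapiens) for cytotoxicity, read by CCK-8 assay, with a stated time of 24 h; a lower number here means that less compound is tolerated, a higher number that more compound is tolerated:
Compound 1 `Cn1cc(SCC(=O)NCc2ccc(Cl)c(Cl)c2)c2ccccc21`: > 100000 nM
Compound 2 `COc1ccccc1CNC(=O)CSc1cn(C)c2ccccc12`: > 100000 nM
Compound 3 `O=C(CSc1c[nH]c2c(Br)cccc12)NCc1ccc(Cl)c(Cl)c1`: > 100000 nM

In this assay compound 1 gives > 100000 nM, which is a limit of the assay and not a number. Compound 2 gives > 100000 nM, again only a limit. Compound 3 gives > 100000 nM, also a limit. Between compound 1 and compound 2 the change is 2-methoxyphenyl in place of 3,4-dichlorophenyl on a saturated chain carbon bound to an amide-type nitrogen, and the step is a step that the two limits leave unreadable from compound 1 to compound 2; with the limit of > 100000 nM in this assay, at which 3 of the 3 values shown sit, the size of this step cannot be read. Compound 4 `COc1ccccc1CNC(=O)CSc1c[nH]c2c(Br)cccc12` differs from compound 3 by 2-methoxyphenyl in place of 3,4-dichlorophenyl on a saturated chain carbon bound to an amide-type nitrogen, the same change at the same place. The cores of compound 1 and compound 3 differ, but that difference is not broken down here. The step from compound 3 to compound 4 is expected to be a step that the limit leaves unreadable from compound 3 to compound 4, because the same change earlier gave a step that the two limits leave unreadable from compound 1 to compound 2 and no change was seen. Compound 4 is expected to give 150000 nM in this assay.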

Compound 4, half-maximal cytotoxic concentration: 72400 nM
Beside the measured number, compound 4's estimate is 2.1-fold (0.32 log units) above it, outside the stated range (below it).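

In this assay compound 3 gives > 100000 nM, which is a limit of the assay and not a number. Putting 2-methoxyphenyl in place of 3,4-dichlorophenyl on the core of compound 3 gives an at least 1.3-fold lower number from compound 3 to compound 4 (0.14 log units; that floor lies within the scatter), so this result alone does not establish a real change. The same swap on the core of compound 1 cannot be read, which means the data neither show that the effect carries from one core to the other nor show that it fails to: the limit of > 100000 nM in this assay, at which 3 of the 4 values shown sit.

The compounds shown leave open how this assay would respond to an amine or a carboxylic acid in place of 2-methoxyphenyl. On these data alone, the true values behind the limits for compound 1, compound 2 and compound 3 also remain open.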